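A few compounds are considered here, and "the series" means these few. Any claim that something is new, unique, unknown or untested is made for them only; others in the source may bear on it.

Measured so far in an ADME assay on Vero cells (Chlorocebus sabaeus) for cytotoxicity, read by MTT assay, with a stated time of 72 h; on this read-out higher numbers stand for lower toxicity in this test and lower numbers for higher toxicity in this test: compound 1 `O=C(/C=C/c1ccco1)Nc1nnc(-c2ccccc2)[nH]1` gives 2180000 nM. Compound 2 `O=C(/C=C/c1cccc(Cl)c1)Nc1nnc(-c2ccccc2)[nH]1` gives 1470000 nM. Compound 3 `O=C(/C=C/c1ccc(O)cc1)Nc1nnc(-c2ccccc2)[nH]1` gives 1850000 nM.

Compound 3 stands second highest of the three numbers, with its nearest neighbour at a 1.2-fold lower number from compound 1 to compound 3 (0.07 log units; within the scatter) and its furthest at a 1.3-fold higher number from compound 2 to compound 3 (0.10 log units; within the scatter); the remaining pair gives a 1.5-fold lower number from compound 1 to compound 2 (0.17 log units; within the scatter). All three steps lie within the scatter, so the three compounds are not separated in this assay.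

Compound 4 `C=C(C)COc1ccc(/C=C/C(=O)Nc2nnc(-c3ccccc3)[nH]2)cc1` differs from compound 3 by 2-methylprop-2-en-1-yl in place of hydrogen on an oxygen on an aromatic ring. Among the compounds with values here, none of the measured steps touches this oxygen: each exchanges the group on the double-bonded chain carbon, and each stays within the scatter. Within the data shown here, no measured step therefore bears directly on this change, and no step beyond the scatter is expected in this assay. The step from compound 3 is estimated as a 1.2-fold lower number from compound 3 to compound 4 (0.09 log units; within the scatter). Compound 4 is expected at 1500000 nM, with a range of 500000 nM to 4000000 nM.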

Compound 4, half-maximal cytotoxic concentration: 1420000 nM
Compound 4: middle estimate off by 1.1-fold (0.02 log units), on the high side, within the range that was stated.
By their numbers in this assay, from the lowest: compounds 4, 2, 3 and 1 (each within the scatter of the next).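

Within the data shown here, this is the first change at the oxygen on an aromatic ring, and in this assay hydroxy to (2-methylprop-2-en-1-yl)oxy gives a 1.3-fold lower number from compound 3 to compound 4 (0.11 log units; within the scatter), with no separation of the two compounds. The step adds 4 heavy atoms at this oxygen without a change beyond the scatter. No data at hand give a cause for this result.

As far as these compounds go, whether an amine, a carboxylic acid or a longer chain on this oxygen would leave the number within the scatter remains open. From the compounds shown here alone, the shared core is the same in all four compounds, so the effect of a change there is also open.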